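This account rests on a few compounds, and the source may have more. Where it says the series, first, only, none or still open, it means among the compounds named here.

Compound 1 `CCCCc1ccc(CNCc2ccccc2)c(=O)n1Cc1ccc(-c2ccccc2-c2nn[nH]n2)cc1` carries a butyl chain on its core and a benzyl group on an amine nitrogen. Going by the values given here, in a functional assay (aorta) for antagonist activity, with Oryctolagus cuniculus as the target (a lower number here means a stronger inhibitor, a higher number a weaker inhibitor), compound 1 gives 1 nM, the lowest of the three numbers measured so far. Compound 2 `CCCCc1ccc(CNC(=O)NC2CCCCC2)c(=O)n1Cc1ccc(-c2ccccc2-c2nn[nH]n2)cc1` bears a cyclohexylcarbamoyl group in place of that benzyl, and in this assay compound 2 gives 90 nM. Compound 3 `CCCCNC(=O)NCc1ccc(CCCC)n(Cc2ccc(-c3ccccc3-c3nn[nH]n3)cc2)c1=O` bears a butylcarbamoyl group in the same place, and in this assay compound 3 gives 10 nM. Both replacements made inhibition weaker: a 90-fold higher number from compound 1 to compound 2 (1.95 log units; beyond the scatter) and a 10-fold higher number from compound 1 to compound 3 (1.00 log units; beyond the scatter), while a 9.0-fold lower number from compound 2 to compound 3 (0.95 log units; beyond the scatter) shows that the two carbamoyl groups are not equivalent to each other.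

Compound 4 `CCCCc1ccc(CNS(=O)(=O)c2ccc(C)cc2)c(=O)n1Cc1ccc(-c2ccccc2-c2nn[nH]n2)cc1` has not been measured. The change from compound 1 is (4-methylphenyl)sulfonyl in place of benzyl on an amine nitrogen. As in compounds 2 and 3, the benzyl leaves and the nitrogen instead carries a group with hydrogen-bond acceptors. Both measured departures from the benzyl raised the number by modest to large amounts, so a weaker inhibitor than compound 1 is expected, most likely between the two earlier outcomes. The expected step is a 30-fold higher number from compound 1 to compound 4 (1.48 log units; beyond the scatter). Compound 4 is therefore estimated at 30 nM in this assay, with a range from 5 nM to 200 nM.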

Compound 4, half-maximal inhibitory concentration: 9 nM
Beside the measured number, compound 4's estimate is 3.3-fold (0.52 log units) above it, within the range that was stated.
By their numbers in this assay, from the lowest: compound 1; then compounds 4 and 3 (each within the scatter of the next); then compound 2.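

The aromatic ring alone does not preserve the number of compound 1: the (4-methylphenyl)sulfonyl group also carries a six-membered aromatic ring of carbon only, yet this assay shows a 9.0-fold higher number from compound 1 to compound 4 (0.95 log units; beyond the scatter). Compared with the butylcarbamoyl group, which has no such ring, the same position gives a 1.1-fold lower number from compound 3 to compound 4 (0.05 log units; within the scatter), so this assay does not separate these two replacements despite their different shapes on paper. Compared with the cyclohexylcarbamoyl group, it gives a 10-fold lower number from compound 2 to compound 4 (1.00 log units; beyond the scatter), which leaves compound 2 with the highest number of the set and shows that replacing the benzyl does not always cost the same amount.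

No measurement shown here explains why these groups differ. The compounds also leave open whether the low number of compound 1 needs the aromatic ring of the benzyl group or only a saturated carbon attached to the nitrogen, a question that a plain butyl group on the amine nitrogen, a 2-phenylethyl group or a methylsulfonyl group could help to settle.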